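The source may report more compounds than this note shows. Statements on the series, on what has been measured and on what is new or still open speak of the compounds shown alone.

Measured so far in a functional assay for inhibition of sodium/hydrogen exchanger (Oryctolagus cuniculus); a lower number here means a stronger inhibitor, a higher number a weaker inhibitor:
- compound 1, `Cc1cc(-c2cc(Cl)cc(Cl)c2)c(S(C)(=O)=O)cc1C(=O)N=C(N)N`: 130 nM
- compound 2, `Cc1cc(OCc2ccccc2)c(S(C)(=O)=O)cc1C(=O)N=C(N)N`: 28 nM
- compound 3, `Cc1cc(Oc2ccc(Cl)cc2)c(S(C)(=O)=O)cc1C(=O)N=C(N)N`: 13 nM

Compound 3 gives the lowest number of the three. Its nearest neighbour is compound 2, a 2.2-fold lower number from compound 2 to compound 3 (0.33 log units; beyond the scatter); the furthest is compound 1, a 10-fold lower number from compound 1 to compound 3 (1.00 log units; beyond the scatter). The remaining step, a 4.6-fold lower number from compound 1 to compound 2 (0.67 log units; beyond the scatter), also points the same way, so within this small set every change at the aromatic carbon in question has moved the number.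

Compound 4, `Cc1cc(N)c(S(C)(=O)=O)cc1C(=O)N=C(N)N`, has not been measured in this assay. Its difference from compound 3 is counted as follows: amino in place of 4-chlorophenoxy on an aromatic carbon. None of the three measured steps tests a change of this kind: each of them swaps one group of several heavy atoms with an aromatic ring for another of similar size, whereas here the whole 4-chlorophenoxy is removed and a single nitrogen enters. The measured steps therefore give the direction of sensitivity at this carbon but not its size for so large a loss of atoms. The expectation for compound 4 is a higher number than for compound 3, of modest size, a 3.8-fold higher number from compound 3 to compound 4 (0.59 log units; beyond the scatter). The estimate for compound 4 in this assay is 50 nM, with a range from 10 nM to 250 nM.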

Compound 4, half-maximal inhibitory concentration: 16 nM
Beside the measured number, compound 4's estimate is 3.1-fold (0.49 log units) above it, and the stated range covers the measured number.
By their numbers in this assay, from the lowest: compounds 3, 4 and 2 (each within the scatter of the next, the first and the last beyond it); then compound 1.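

In this assay the step of a 1.2-fold higher number from compound 3 to compound 4 (0.09 log units; within the scatter) shows that this aromatic carbon, ortho to the methylsulfonyl group, tolerates the loss of the whole 4-chlorophenoxy, with its 8 heavy atoms and aromatic ring, and the entry of amino with 1 heavy atom. The step of a 1.8-fold lower number from compound 2 to compound 4 (0.24 log units; within the scatter) also leaves compound 4 unseparated from the benzyloxy compound, so neither an aromatic ring nor a large group at this carbon is required for a number of this size in the series shown. Only 3,5-dichlorophenyl stands apart from amino, in the step of an 8.1-fold lower number from compound 1 to compound 4 (0.91 log units; beyond the scatter) and this makes that group, rather than the smaller size of amino, the exception among the four compounds; nothing at hand explains these numbers.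

Still open, from the compounds shown here alone, is how far the group at this carbon can be reduced, since a bare hydrogen or a hydroxyl would test whether amino itself contributes anything. Methylamino, dimethylamino and acetylamino would show whether the amino hydrogens matter, and anilino would set an aromatic ring on nitrogen against the 4-chlorophenoxy on oxygen.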